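Replacing the methanesulfonamido group on the aryl ring of compound 1

The compounds below may be only part of what the source reports. "The series", "measured", "known", "first", "only" and "open" are said of these compounds alone.

Compound 1 `CS(=O)(=O)Nc1ccc(-c2cc(C(=O)N[C@H]3CCCNC3)c(NC(N)=O)s2)cc1` carries a methanesulfonamido group on its pendant aryl ring; in an assay on isolated protein for inhibition of cyclin-dependent kinase 2-associated protein 1 (Homo sapiens) (on this read-out higher numbers stand for weaker inhibition and lower numbers for stronger inhibition), compound 1 gives "not determined" (no result reported), so no number places it within the series. Within the data shown here, the only measured analogues are compound 2 `CN(C)c1ccc(-c2cc(C(=O)N[C@H]3CCCNC3)c(NC(N)=O)s2)cc1`, which in this assay gives 8400 nM, and compound 3 `Cc1ccc(-c2cc(C(=O)N[C@H]3CCCNC3)c(NC(N)=O)s2)cc1`, which gives 5500 nM. Among the measured compounds shown here, the one measured step, a 1.5-fold lower number from compound 2 to compound 3 (0.18 log units; within the scatter), concerns methyl in place of dimethylamino on an aromatic carbon and does not touch the change at hand.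

Compound 4 `NC(=O)Nc1sc(-c2ccc(C(=O)N3CCCCC3)cc2)cc1C(=O)N[C@H]1CCCNC1` differs from compound 1 as follows: (piperidin-1-yl)carbonyl in place of methanesulfonamido on an aromatic carbon. For the measured compounds named here, no measured step bears on this exchange, and compound 1 itself has no value, so no direction or size of change can be derived; the expectation rests only on compound 2 and compound 3 lying close together on this read-out. Compound 4 is therefore expected to fall near them, estimated at 7000 nM with a range from 1500 nM to 30000 nM.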

Compound 4, half-maximal inhibitory concentration: 10800 nM
Beside the measured number, compound 4's estimate is 1.5-fold (0.19 log units) below it; measured number inside the range.
By their numbers in this assay, from the lowest: compounds 3, 2 and 4 (each within the scatter of the next).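

At this aromatic carbon, a group carrying a six-membered non-aromatic ring gives no separation from the smaller groups in this assay: (piperidin-1-yl)carbonyl in place of methyl gives a 2.0-fold higher number from compound 3 to compound 4 (0.29 log units; within the scatter), and in place of dimethylamino it gives a 1.3-fold higher number from compound 2 to compound 4 (0.11 log units; within the scatter). Methyl, dimethylamino and (piperidin-1-yl)carbonyl therefore sit together on this read-out, and none of the three stands apart from the other two. Nothing on hand offers a reason for this result.

With no number for compound 1, the exchange of methanesulfonamido for (piperidin-1-yl)carbonyl cannot be read. From the compounds shown here alone, whether a carboxylic acid or a primary amine at this aromatic carbon would stay with these three remains open.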